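Dropping the hydroxy group from compound 2

The source may report more compounds than this note shows. Statements on the series, on what has been measured and on what is new or still open speak of the compounds shown alone.

Compound 2 (`COc1cc(/C=C/c2nnc(NC(=O)c3cccc(O)c3)s2)c(Br)c(OC)c1OC`) gives 360 nM in a functional assay on MCF7 cells (Homo sapiens) for antiproliferative activity, read by MTT assay, with a stated time of 48 h (a lower number here means a stronger inhibitor, a higher number a weaker inhibitor), and compound 1 (`COc1cc(/C=C/c2nnc(NC(=O)c3cccc(Cl)c3)s2)c(Br)c(OC)c1OC`) gives 230 nM there, so the two stand within the scatter of each other. Compound 3 (`COc1cc(/C=C/c2nnc(NC(=O)c3ccccc3)s2)c(Br)c(OC)c1OC`) carries hydrogen in place of hydroxy on an aromatic carbon, which turns 3-hydroxyphenyl to phenyl. Among the compounds with values here, the only measured step bearing on this, chloro to hydroxy at that carbon, is a 1.6-fold higher number from compound 1 to compound 2 (0.19 log units; within the scatter) and stays within the scatter. No step beyond the scatter is therefore expected in this assay and the estimate is a 1.1-fold lower number from compound 2 to compound 3 (0.05 log units; within the scatter) with no firm direction. Compound 3 is expected at 320 nM with 130 nM to 800 nM as the estimated range.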

Compound 3, half-maximal inhibitory concentration: 290 nM
Beside the measured number, compound 3's estimate is 1.1-fold (0.04 log units) above it; low and high end bracket the measured number.
By their numbers in this assay, from the lowest: compounds 1, 3 and 2 (each within the scatter of the next).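

In this assay the step to hydrogen reads a 1.2-fold lower number from compound 2 to compound 3 (0.09 log units; within the scatter) and the step from chloro reads a 1.3-fold higher number from compound 1 to compound 3 (0.10 log units; within the scatter). With hydrogen now available as a reference, neither hydroxy nor chloro on this aromatic carbon moves the number beyond the scatter, so these three compounds show no measurable dependence on the change. No evidence is available that bears on this result. From the compounds shown here alone, whether an amine, a carboxylic acid or a longer chain such as butoxy on this carbon would stay within the scatter remains open, as does whether the same holds on the ring's other carbons.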